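This account rests on a few compounds, and the source may have more. Where it says the series, first, only, none or still open, it means among the compounds named here.

Compound 3 `CN(C)C(=O)c1cc2cnc(Nc3ccc(NC(=O)C4(C(=O)Nc5cccc(C(F)(F)F)c5)CC4)cc3)nc2n1C1CCCC1` stands second highest of the three compounds tested in a functional assay on T47D cells (Homo sapiens) for inhibition, read by CCK-8 assay, with a stated time of 72 h, tested at 10 uM (a higher number here means more inhibition of growth at the concentration tested, a lower number less inhibition of growth), where compound 3 gives 92.7%. The nearest number belongs to compound 1 `CN(C)C(=O)c1cc2cnc(Nc3ccc(NC(=O)C4(C(=O)Nc5ccccc5F)CC4)cc3)nc2n1C1CCCC1`, which gives 97.8%, a gap within the usual scatter, while compound 2 `CN(C)C(=O)c1cc2cnc(Nc3ccc(NC(=O)C4(C(=O)Nc5ccc(F)cc5)CC4)cc3F)nc2n1C1CCCC1` gives 67.9%, a gap beyond it. Compound 4 `CN(C)C(=O)c1cc2cnc(Nc3ccc(NC(=O)C4(C(=O)Nc5cccc(F)c5)CC4)cc3)nc2n1C1CCCC1` differs from compound 3 in one place: fluoro in place of trifluoromethyl on an aromatic carbon. For the measured compounds named here, one measured step bears on this change, since it also exchanges the group on an amide-type nitrogen: a number 5.1 percentage points lower from compound 1 to compound 3 (within the scatter). Because a number 5.1 percentage points lower from compound 1 to compound 3 (within the scatter) stayed within the scatter, no step beyond the scatter is expected for compound 4, a number 0.7 percentage points lower from compound 3 to compound 4 (within the scatter). Compound 4 is therefore estimated to give 92% in this assay, with a range from 80% to 100%.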

Compound 4, percent growth inhibition at one concentration: -0.4%
Compound 4: middle estimate off by 92.4 percentage points, on the high side, outside the stated range (below it).
By their numbers in this assay, from the lowest: compound 4; then compound 2; then compounds 3 and 1 (each within the scatter of the next).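

Fluoro in place of trifluoromethyl on this aromatic carbon brings a number 93.1 percentage points lower from compound 3 to compound 4 (beyond the scatter) in this assay and so removes the growth inhibition entirely. Moving the single fluoro, from 2-fluorophenyl to 3-fluorophenyl, brings a number 98.2 percentage points lower from compound 1 to compound 4 (beyond the scatter) and shows that this ring is far less forgiving than the earlier small step suggested. Among these compounds, the identity and place of one group can separate strong inhibition from none. On these data alone, whether a chloro or a methoxy group on this aromatic carbon would behave like trifluoromethyl or like fluoro stays open. Nothing measured here gives a reason for this loss.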